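A Methoxyphenyl Variant Within a Small Aryl-Amide Series

The compounds below may be only part of what the source reports. "The series", "measured", "known", "first", "only" and "open" are said of these compounds alone.

Compound 3 `O=C(Nc1ccc(Oc2ccnc3[nH]ccc23)cc1)c1cn(-c2ccc(C(F)(F)F)cc2Cl)c2ccccc2c1=O` holds the highest number of the three compounds measured in a functional assay on A549 cells (Homo sapiens) for inhibition, read by MTT assay, with a stated time of 72 h; a higher number here means a weaker inhibitor, a lower number a stronger inhibitor; compound 3 gives 2350 nM. Compound 1 `O=C(Nc1ccc(Oc2ccnc3[nH]ccc23)cc1)c1cn(-c2ccccc2)c2ccccc2c1=O` gives 1030 nM, and compound 2 `O=C(Nc1ccc(Oc2ccnc3[nH]ccc23)cc1)c1cn(-c2ccc(Br)cc2F)c2ccccc2c1=O` gives 1330 nM. Among the steps that connect them, a 2.3-fold higher number from compound 1 to compound 3 (0.36 log units; beyond the scatter) is the only one beyond the scatter, whereas a 1.3-fold higher number from compound 1 to compound 2 (0.11 log units; within the scatter) and a 1.8-fold higher number from compound 2 to compound 3 (0.25 log units; within the scatter) both remain within it.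

Compound 4 `COc1ccc(-n2cc(C(=O)Nc3ccc(Oc4ccnc5[nH]ccc45)cc3)c(=O)c3ccccc32)cc1` has not yet been measured. It differs from compound 3 in one place: 4-methoxyphenyl in place of 2-chloro-4-(trifluoromethyl)phenyl on an aromatic nitrogen. For the measured compounds named here, the measured steps that bear on this change are those among compounds 1, 2 and 3, in which three different groups on the same aromatic nitrogen gave numbers spanning only a modest range, with compound 1, carrying phenyl, separated from compound 3 by the single step beyond the scatter. A return toward a phenyl carrying only a methoxy is therefore expected to undo much of the step of a 2.3-fold higher number from compound 1 to compound 3 (0.36 log units; beyond the scatter), so the step of a 2.1-fold lower number from compound 3 to compound 4 (0.33 log units; beyond the scatter) is expected to be modest and downward. Compound 4 is accordingly estimated at 1100 nM in this assay, within a range from 500 nM to 2500 nM.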

Compound 4, half-maximal inhibitory concentration: 4980 nM
Beside the measured number, compound 4's estimate is 4.5-fold (0.66 log units) below it; measured number outside the range, above it.
By their numbers in this assay, from the lowest: compounds 1, 2 and 3 (each within the scatter of the next, the first and the last beyond it); then compound 4.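

In this assay, the 4-methoxyphenyl group gives the weakest inhibitor of the four at this aromatic nitrogen, with a 2.1-fold higher number from compound 3 to compound 4 (0.33 log units; beyond the scatter), a 3.7-fold higher number from compound 2 to compound 4 (0.57 log units; beyond the scatter) and a 4.8-fold higher number from compound 1 to compound 4 (0.68 log units; beyond the scatter). The earlier compounds shown here showed only a narrow span at this position, and the position now proves not to be indifferent to its group: a single methoxy in place of hydrogen moves the number further than the replacement with two substituents did in a 2.3-fold higher number from compound 1 to compound 3 (0.36 log units; beyond the scatter), so the number of substituents on this phenyl does not order the results. Nothing available here accounts for why the methoxy group raises the number in this way.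

Whether the rise belongs to the oxygen of the methoxy or simply to any group in that place stays open, as a hydroxy group, a methyl group and a longer ethoxy chain do not appear among the compounds shown. How a dimethylamino group or a carboxylic acid on this phenyl would compare, and whether the same order holds outside these cells, also remains unanswered.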